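Ring ether epimer in a prostaglandin agonist series

A few compounds are considered here, and "the series" means these few. Any claim that something is new, unique, unknown or untested is made for them only; others in the source may bear on it.

Measured so far:
compound 1 `O=C(O)CCC[C@@H]1CC[C@@H]2[C@@H](/C=C/[C@@H](O)COc3ccccc3)[C@H](O)C[C@@H]2O1` — 4.1 nM
compound 2 `O=C(O)CC[C@@H]1CC[C@@H]2[C@@H](/C=C/[C@@H](O)COc3ccccc3)[C@H](O)C[C@@H]2OC1` — 1000 nM

In a functional assay on CHO cells for agonist activity at prostaglandin F2-alpha receptor (Homo sapiens), read by fluorescence and calcium flux (on this read-out higher numbers stand for an effect only at larger amounts of compound and lower numbers for an effect already at smaller amounts), compound 1 gives 4.1 nM and compound 2 gives 1000 nM; compound 2 thus holds the higher of the two numbers, and its gap to compound 1 lies beyond the scatter. Compound 3 `O=C(O)CC[C@H]1CC[C@@H]2[C@@H](/C=C/[C@@H](O)COc3ccccc3)[C@H](O)C[C@@H]2OC1` is next. It differs from compound 2 as follows: the two compounds have the same atoms and bonds and differ only in configuration as drawn: 1 of 7 stereo elements differ; a stereocentre at a saturated ring carbon is drawn S in compound 2 and R in compound 3. For the measured compounds named here, no measured pair shows a change of this kind, so the step is open in both size and direction. A moderate downward step is expected, a 3.3-fold lower number from compound 2 to compound 3 (0.52 log units; beyond the scatter), with a wide range. Compound 3 is estimated at 300 nM in this assay, between 30 nM and 3000 nM.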

Compound 3, half-maximal effective concentration: 110 nM
Beside the measured number, compound 3's estimate is 2.7-fold (0.44 log units) above it; the range from low to high includes it.
By their numbers in this assay, from the lowest: compound 1; then compound 3; then compound 2.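

In this assay, redrawing a stereocentre at a saturated ring carbon from S to R gives a 9.1-fold lower number from compound 2 to compound 3 (0.96 log units; beyond the scatter). For the compounds shown here, this is the first step that can be read at a single place, so the position is sensitive to configuration alone. The change in number can be assigned to that one stereocentre because nothing else separates the pair: the fact that compounds 2 and 3 differ only in the configuration as drawn

Compound 1 differs from both compounds in more than one place, so it gives no reading of this configuration on its own core. As far as these compounds go, whether the same preference holds with a longer chain, or with a methyl ester in place of the carboxylic acid, remains open.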